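Moving the carboxylic acid around the terminal phenyl ring

The compounds below may be only part of what the source reports. "The series", "measured", "known", "first", "only" and "open" are said of these compounds alone.

Measured compounds:
compound 1 `Cc1c(OCCCCOc2ccccc2C(=O)O)ccc(C(=O)CC(C)C)c1O` 415 nM
compound 2 `CCCC(=O)c1ccc(OCCCCOc2ccc(C(=O)O)cc2C)c(C)c1O` 104 nM
compound 3 `Cc1c(OCCCCOc2ccccc2C(=O)O)ccc(C(=O)CC2CCCC2)c1O` 335 nM

In an assay on HEK293 cells for positive allosteric modulation of metabotropic glutamate receptor 2 (Rattus norvegicus), read by thallium flux, with a stated time of 2.5 min (a higher number here means that more compound is needed for the effect, a lower number that less compound is needed), compound 1 gives the highest number of the three, 415 nM. Its nearest neighbour is compound 3 at 335 nM, and the one step listed between these compounds, a 1.2-fold lower number from compound 1 to compound 3 (0.09 log units; within the scatter), lies within the scatter. Compound 2 at 104 nM stands furthest from compound 1, but it differs from compound 1 in two places, so no single step can be read from that pair.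

Compound 4 `Cc1c(OCCCCOc2ccc(C(=O)O)cc2F)ccc(C(=O)CC(C)C)c1O` has not yet been measured. Compared with compound 1 the change is 4-carboxy-2-fluorophenyl in place of 2-carboxyphenyl on an oxygen on a saturated carbon. Going by the values given here, none of the measured steps touches this part of the molecule: the step from compound 1 to compound 3 concerns the chain carbon bound to the carbonyl and is within the scatter, so it says nothing about the terminal ring. Among the compounds with values here, the only hint is that compound 2, whose acid-bearing ring also differs from that of compound 1, gives a lower number, though a second change is mixed in there.

Compound 4 is therefore expected to give 180 nM, with a range of 60 nM to 550 nM, a step estimated as a 2.3-fold lower number from compound 1 to compound 4 (0.36 log units; beyond the scatter).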

Compound 4, half-maximal effective concentration: 102 nM
Beside the measured number, compound 4's estimate is 1.8-fold (0.25 log units) above it, and the stated range covers the measured number.
By their numbers in this assay, from the lowest: compounds 4 and 2 (each within the scatter of the next); then compounds 3 and 1 (each within the scatter of the next).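

In this assay, the terminal ring proves to be a place where a single change moves the number beyond the scatter: 4-carboxy-2-fluorophenyl in place of 2-carboxyphenyl gives a 4.1-fold lower number from compound 1 to compound 4 (0.61 log units; beyond the scatter) on the otherwise unchanged core of compound 1. The earlier single change at the saturated chain carbon bound to the carbonyl carbon, a 1.2-fold lower number from compound 1 to compound 3 (0.09 log units; within the scatter), did not do so. Nothing in the data explains why the new ring lowers the number.

From the compounds shown here alone, this one step combines a new place for the carboxylic acid with an added fluorine, so the share of each remains open. Also open, going by these compounds, is whether the step holds with chlorine in place of the fluorine, with a tetrazole in place of the carboxylic acid, or with the cyclopentyl chain of compound 3.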